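A few compounds are considered here, and "the series" means these few. Any claim that something is new, unique, unknown or untested is made for them only; others in the source may bear on it.

In a functional assay on the whole organism for inhibition, with Scenedesmus acutus as the target (on this read-out higher numbers stand for weaker inhibition and lower numbers for stronger inhibition), compound 1 `O=C1C2=C(CCCC2)C(=O)N1c1ccc(Cl)cc1F` gives 37.2 nM and compound 2 `COC(=O)c1cc(N2C(=O)C3=C(CCCC3)C2=O)ccc1Cl` gives 1780 nM as its reading. Compound 2 thus holds the higher of the two numbers, beyond the scatter, and is the weaker inhibitor of this pair. Compound 3 `COC(=O)c1cc(N2C(=O)C3=C(CCCC3)C2=O)c(F)cc1Cl` differs from compound 2 by fluoro in place of hydrogen on an aromatic carbon. Within the data shown here, no measured pair isolates this change, but compound 1 (37.2 nM) also carries a fluoro group. In this assay a step to stronger inhibition, beyond the scatter, is therefore expected (a 7.1-fold lower number from compound 2 to compound 3 (0.85 log units; beyond the scatter)). Compound 3 is estimated at 250 nM (range 50 nM to 1000 nM).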

Compound 3, half-maximal inhibitory concentration: 67.6 nM
For compound 3 the middle estimate is 3.7-fold (0.57 log units) above the measured one, and the stated range covers the measured number.
By their numbers in this assay, from the lowest: compounds 1 and 3 (each within the scatter of the next); then compound 2.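

In this assay, fluoro on this aromatic carbon, ortho to a large group and para to a methoxycarbonyl group, gives a 26-fold lower number from compound 2 to compound 3 (1.42 log units; beyond the scatter), so a single added atom here can strongly raise inhibition. With fluoro in place, methoxycarbonyl in place of hydrogen gives only a 1.8-fold higher number from compound 1 to compound 3 (0.26 log units; within the scatter), so compound 1 and compound 3 cannot be told apart on this read-out. No measurement here explains the size of the fluoro step. Going by these compounds, it remains open whether a methyl or methoxy group at the fluoro position would do the same, and whether a carboxylic acid could stand in for the methoxycarbonyl group.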